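Chain extension from methyl to ethyl to propyl

A few compounds are considered here, and "the series" means these few. Any claim that something is new, unique, unknown or untested is made for them only; others in the source may bear on it.

Measured compounds:
- compound 1 `Cc1ccc(OC[C@@H]2CCN2)cn1`: in an assay on brain for binding affinity to Neuronal acetylcholine receptor; alpha4/beta2 (Rattus norvegicus), read by radioligand binding (a higher number here means a weaker inhibitor, a lower number a stronger inhibitor), compound 1 gives 0.057 nM
- compound 2 `CCc1ccc(OC[C@@H]2CCN2)cn1`: compound 2 gives 19 nM
- compound 3 `CCc1cncc(OC[C@@H]2CCN2)c1`: compound 3 gives 0.1 nM

Compound 2 differs from compound 1 by methyl in place of hydrogen on a saturated chain carbon bound to an aromatic carbon. That change made a 330-fold higher number from compound 1 to compound 2 (2.52 log units; beyond the scatter), a large loss in this assay. Compound 3 carries the same ethyl group, but on a different core; the difference between the core of compound 3 and the core of compound 1 is not broken down here. Compound 3 sits within the scatter of compound 1, so no order between those two can be drawn, while compound 2 stands far higher than both.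

Compound 4 `CCCc1cncc(OC[C@@H]2CCN2)c1` is not yet measured. It differs from compound 3 by methyl in place of hydrogen on a saturated chain carbon, two bonds along the chain from an aromatic carbon. Among the measured compounds shown here, this is the same kind of change as the one from compound 1 to compound 2, though not the same: there the new methyl sits on a saturated chain carbon bound to an aromatic carbon, here it sits two bonds along the chain from an aromatic carbon, and the cores also differ.

Given that compound 3 is already the ethyl analogue and that lengthening the chain cost compound 2 so much relative to compound 1, a further loss is expected for compound 4, estimated at a 30-fold higher number from compound 3 to compound 4 (1.48 log units; beyond the scatter). For the measured compounds named here, the estimate for compound 4 is 3 nM, with a range from 0.2 nM to 50 nM, because the only comparable step is a 330-fold higher number from compound 1 to compound 2 (2.52 log units; beyond the scatter) on another core and at another place on the chain.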

Compound 4, inhibition constant: 0.039 nM
Compound 4: the middle estimate sits 77-fold (1.89 log units) above what was measured; measured number outside the range, below it.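

In this assay, the added methyl gives a 2.6-fold lower number from compound 3 to compound 4 (0.41 log units; beyond the scatter), a modest step that leaves the propyl compound with a lower number than its ethyl neighbour on this core, and the large loss seen on the core of compound 1 does not reappear. The same kind of change therefore cannot be carried from one core to the other as a fixed increment, since the two steps differ in direction and in size: the same change on two cores in this assay, a 330-fold higher number (2.52 log units; beyond the scatter) from compound 1 to compound 2 and a 2.6-fold lower number (0.41 log units; beyond the scatter) from compound 3 to compound 4, 850-fold (2.93 log units) apart, beyond the scatter of two such steps This pair does not show that the core alone sets the outcome: the new methyl sits on a saturated chain carbon bound to an aromatic carbon in the earlier step and two bonds along the chain from an aromatic carbon in the new one, and these compounds do not separate core from place or give any cause for the gap.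

Open, as far as these compounds go, is how a propyl chain behaves on the core of compound 1, which would compare the two cores with the same chain. Also open, from the compounds shown here alone, is whether a butyl chain or a branched isopropyl group on the core of compound 4 would hold the number seen for the propyl chain or lose it.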